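A few compounds are considered here, and "the series" means these few. Any claim that something is new, unique, unknown or untested is made for them only; others in the source may bear on it.

Of the compounds shown here, three that share one core have been tested in an ADME assay on MT4 cells (Homo sapiens) for cytotoxicity, read by MTT assay, with a stated time of 4 days; a higher number here means that more compound is tolerated, a lower number that less compound is tolerated. Compound 1 `C/C(=N\NC(=O)COc1cccc2ccccc12)c1ccc(C#N)cc1Br` gives 12.1 ug/mL, compound 2 `C/C(=N\NC(=O)COc1cccc2ccccc12)c1ccc(O)cc1O` gives 59.9 ug/mL, and compound 3 `C/C(=N\NC(=O)COc1cccc2ccccc12)c1ccc(O)cc1` gives 68.8 ug/mL. Compound 3 thus holds the highest of the three numbers; its gap to compound 2 stays within the scatter, while compound 1 sits clearly lower, as the steps of a 5.0-fold higher number from compound 1 to compound 2 (0.69 log units; beyond the scatter) and a 5.7-fold higher number from compound 1 to compound 3 (0.75 log units; beyond the scatter) show. Compound 4 `C/C(=N\NC(=O)COc1cccc2ccccc12)c1ccc([N+](=O)[O-])cc1` has not yet been measured. It differs from compound 3 in one place: nitro in place of hydroxy on an aromatic carbon. Going by the values given here, no measured pair swaps a hydroxy for a nitro, so the guide is indirect. The step of a 1.1-fold higher number from compound 2 to compound 3 (0.06 log units; within the scatter) shows that taking the hydroxy off this ring changed little, whereas both larger steps came with the exchange of a 2-bromo-4-cyanophenyl for a hydroxyphenyl. Among the compounds with values here, because compound 1 gives 12.1 ug/mL and is the only member without a hydroxy on that ring, the expected step for compound 4 is a 2.0-fold lower number from compound 3 to compound 4 (0.29 log units; within the scatter). Compound 4 is estimated at 35 ug/mL, within a range from 15 ug/mL to 80 ug/mL.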

Compound 4, half-maximal cytotoxic concentration: 89.3 ug/mL
For compound 4 the middle estimate is 2.6-fold (0.41 log units) below the measured one, and the stated range ends below it.
By their numbers in this assay, from the lowest: compound 1; then compounds 2, 3 and 4 (each within the scatter of the next).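

In this assay, a hydroxy and a nitro on the aromatic carbon para to a large group read alike, with a 1.3-fold higher number from compound 3 to compound 4 (0.11 log units; within the scatter), even though the nitro has more heavy atoms and no hydrogen-bond donor. With a 1.5-fold higher number from compound 2 to compound 4 (0.17 log units; within the scatter) as well, compound 4 shows that a ring without a hydroxy can stay level with the hydroxyphenyl compounds, so the missing hydroxy alone does not account for the low number of compound 1, which stays apart with a 7.4-fold higher number from compound 1 to compound 4 (0.87 log units; beyond the scatter). No measurement shown here explains any of these results.

It remains open whether the bromo, the nitrile or the two together go with the low number of compound 1, as no compound shown carries only one of them. From the compounds shown here alone, how an amine or a carboxylic acid would read at this position is also open.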